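Fluoro to Hydrogen: What Compound 4 May Show

This account rests on a few compounds, and the source may have more. Where it says the series, first, only, none or still open, it means among the compounds named here.

Compound 1, `COc1cc(OC)cc(-c2ccc(-c3ccc(C(=N)N)c(F)c3)s2)c1`, gives 473 nM in a functional assay on UO-31 cells (Homo sapiens) for inhibition, read by sulforhodamine B assay, with a stated time of 48 h; on this read-out lower numbers stand for stronger inhibition of growth and higher numbers for weaker inhibition of growth. Compound 2, `N=C(N)c1ccc(-c2ccc(-c3ccc(Cl)cc3)s2)cc1F`, gives 1720 nM in this assay. Compound 3, `N=C(N)c1ccc(-c2ccc(-c3ccc(Cl)cc3)s2)cc1`, gives 175 nM in this assay.

Compound 1 and compound 2 have different cores; the difference between the two cores is not broken down here. Compound 2 and compound 3 differ in one place, (hydrogen in place of fluoro on an aromatic carbon), and that change produced a 9.8-fold lower number from compound 2 to compound 3 (0.99 log units; beyond the scatter). Compound 4, `COc1cc(OC)cc(-c2ccc(-c3ccc(C(=N)N)cc3)s2)c1`, has not been measured and stands to compound 1 as compound 3 stands to compound 2: hydrogen in place of fluoro on an aromatic carbon, the same change at the same place. For the measured compounds named here, for compound 4 a step of a 5.9-fold lower number from compound 1 to compound 4 (0.77 log units; beyond the scatter) is expected, kept a little smaller than the earlier one because the only guide is the single step of a 9.8-fold lower number from compound 2 to compound 3 (0.99 log units; beyond the scatter). Compound 4 is thus estimated at 80 nM, between 25 nM and 250 nM.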

Compound 4, concentration for 50% growth inhibition: 1770 nM
Beside the measured number, compound 4's estimate is 22-fold (1.34 log units) below it, and the stated range ends below it.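

In this assay, hydrogen in place of fluoro on an aromatic carbon gave a 3.7-fold higher number from compound 1 to compound 4 (0.57 log units; beyond the scatter), and the same change went in opposite directions on the two cores: the same change on two cores in this assay, a 9.8-fold lower number (0.99 log units; beyond the scatter) from compound 2 to compound 3 and a 3.7-fold higher number (0.57 log units; beyond the scatter) from compound 1 to compound 4, 37-fold (1.57 log units) apart, beyond the scatter of two such steps

In this series, then, the step seen on one core did not give even the direction of the step on the other. For the compounds shown here, with only two pairs, this does not show why the cores part ways, and it sets no rule for any further core.

The compounds shown leave open what a methyl or a nitrile in place of the fluoro would do on either core. Also open, going by these compounds, is how the step would run if an amine or a carboxylic acid took the place of the chloro or the methoxy groups.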